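The compounds below may be only part of what the source reports. "The series", "measured", "known", "first", "only" and "open" are said of these compounds alone.

Measured so far in a functional assay on Bel-7402 cells (Homo sapiens) for cytotoxicity, read by MTT assay, with a stated time of 24 h; a higher number here means a weaker inhibitor, a lower number a stronger inhibitor:
- compound 1 `COC(=O)[C@H](NC(=O)Cn1cc(C2=C(c3c[nH]c4ccccc34)C(=O)N(C)C2=O)c2ccccc21)[C@@H](C)O`: a limit of the assay, > 100000 nM
- compound 2 `COC(=O)[C@@H](CO)NC(=O)Cn1cc(C2=C(c3c[nH]c4ccccc34)C(=O)N(C)C2=O)c2ccccc21`: 67200 nM

Among the compounds with values here, compound 2 holds the only actual number in this assay; the other entry is a limit (the limit of > 100000 nM in this assay, at which 1 of the 2 values shown sits). Within the data shown here, the single measured step, an at least 1.4-fold lower number from compound 1 to compound 2 (0.17 log units; that floor lies within the scatter), sits within the scatter and its floor is set by that limit, so it gives no firm direction.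

Compound 3 `COC(=O)CC[C@@H](NC(=O)Cn1cc(C2=C(c3c[nH]c4ccccc34)C(=O)N(C)C2=O)c2ccccc21)C(=O)OC` is next. It differs from compound 2 by (methoxycarbonyl)methyl in place of hydroxy on a saturated chain carbon, two bonds along the chain from an amide-type nitrogen and a carbonyl carbon. Among the measured compounds shown here, no measured step touches this position or this kind of exchange; the step from compound 1 to compound 2 alters the same side chain but only by a methyl, and it was too small to read. The expectation for compound 3 therefore rests on compound 2 alone, with a wide range: the step of a 1.2-fold higher number from compound 2 to compound 3 (0.08 log units; within the scatter) is expected to be small, of no clear direction. Compound 3 is estimated at 80000 nM, between 25000 nM and 250000 nM.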

Compound 3, half-maximal inhibitory concentration: 47400 nM
Compound 3: middle estimate off by 1.7-fold (0.23 log units), on the high side; the measured number falls inside the stated range.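

In this assay, the exchange of hydroxy for (methoxycarbonyl)methyl on this saturated chain carbon gives no readable difference: a 1.4-fold lower number from compound 2 to compound 3 (0.15 log units; within the scatter). Compound 1 stands at a limit of the assay, > 100000 nM. With 2-(methoxycarbonyl)ethyl in place of 1-hydroxyethyl, the series shows its first step beyond the scatter, an at least 2.1-fold lower number from compound 1 to compound 3 (0.32 log units; beyond the scatter), and the size of that step is only a floor set by the limit: the limit of > 100000 nM in this assay, at which 1 of the 3 values shown sits.

Open, on these data alone, is what a carboxylic acid in place of the methoxycarbonyl of the 2-(methoxycarbonyl)ethyl group, or an amine on the same chain, would do to the number. Also open is whether a longer chain would give a step beyond the scatter from compound 2, which the side chains shown do not settle.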